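The source may report more compounds than this note shows. Statements on the series, on what has been measured and on what is new or still open speak of the compounds shown alone.

Compound 1 `CCOC(=O)c1ccc(NC(=O)NCc2cocn2)cc1` is one of three compounds tested in an assay on isolated protein for activation of Nicotinamide phosphoribosyltransferase (Homo sapiens); on this read-out lower numbers stand for an effect already at smaller amounts and higher numbers for an effect only at larger amounts of compound. In this assay compound 1 gives 27600 nM. Compound 2 `CCOC(=O)c1ccc(N/C(=N\C#N)NCc2ccncc2)cc1`, which carries a different linking group and a different ring at the end of its chain, gives 41400 nM in this assay, and the two numbers lie within the usual scatter of each other, so nothing separates them. Compound 3 `O=C(NCc1cnco1)Nc1ccc(S(=O)(=O)c2cccc(OC(F)(F)F)c2)cc1`, which has a sulfone-bearing group in place of the ethyl ester, gives 70 nM in this assay, a far lower number than that of compound 1, well beyond the scatter.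

Compound 4 `CCOC(=O)c1ccc(NC(=O)NCc2ccncn2)cc1` has not yet been measured. It differs from compound 1 in one place: pyrimidin-4-yl in place of 1,3-oxazol-4-yl on a saturated chain carbon bound to an amide-type nitrogen. Going by the values given here, nothing among the measured compounds isolates this exchange of one small aromatic ring for another on the chain, so no step can be read from them.

Among the compounds with values here, with no comparable step in hand, the expectation for compound 4 is a change no larger than the scatter, expressed as a 1.3-fold lower number from compound 1 to compound 4 (0.10 log units; within the scatter). The estimate for compound 4 in this assay is therefore 22000 nM, with a range from 7000 nM to 70000 nM.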

Compound 4, half-maximal effective concentration: 13600 nM
For compound 4 the middle estimate is 1.6-fold (0.21 log units) above the measured one; the measured number falls inside the stated range.
By their numbers in this assay, from the lowest: compound 3; then compound 4; then compounds 1 and 2 (each within the scatter of the next).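

In this assay, going by these compounds alone, this is the first pair of compounds that differ in one place only, and it shows that the ring on a saturated chain carbon bound to an amide-type nitrogen is not a matter of indifference: pyrimidin-4-yl in place of 1,3-oxazol-4-yl gives a 2.0-fold lower number from compound 1 to compound 4 (0.31 log units; beyond the scatter). The step is modest and only just beyond the usual scatter, yet it shows that a five-membered aromatic ring can give way to a six-membered one, with one more heavy atom and the same count of hydrogen-bond acceptors, without the number rising. Nothing measured on these two rings accounts for the step, so its cause stays unknown.

The compounds shown leave open whether the ring needs its hetero atoms at all, which a plain phenyl ring in the same place would test, and whether a longer chain between the ring and the amide-type nitrogen would be accepted. They also leave open whether the same ring exchange would lower the number further on compound 3, which stands at 70 nM.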